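The compounds below may be only part of what the source reports. "The series", "measured", "known", "first", "only" and "open" are said of these compounds alone.

Compound 1 `O=C(N[C@@H]1C[C@H](C(=O)NO)N(S(=O)(=O)c2ccc(Cl)c(Cl)c2)C1)c1cccs1` is a hydroxamic acid on a five-membered ring, and in an assay on isolated protein for inhibition of matrix metalloproteinase-9 (Homo sapiens), read by fluorescence, with stated times of 5 min and 30 min (a lower number here means a stronger inhibitor, a higher number a weaker inhibitor), compound 1 gives 100 nM. Compound 2 `O=C(N[C@H]1C[C@H](C(=O)NO)N(S(=O)(=O)c2ccc(Cl)c(Cl)c2)C1)c1cccs1` is its epimer, and in this assay compound 2 is reported as "not active" (no number reported). The only difference between these two is the fact that compounds 1 and 2 differ only in the configuration as drawn, which shows how strongly the configuration at that ring carbon matters in this series. Compound 3 `O=C(NO)[C@H]1C[C@@H](NS(=O)(=O)c2ccc(-c3ccccc3)cc2)CN1S(=O)(=O)c1ccc(Cl)c(Cl)c1` carries a biphenylsulfonamide in place of the thiophene amide, and in this assay compound 3 gives 590 nM, the higher of the two reported numbers and beyond the scatter from compound 1. Compound 4 `O=C(NO)[C@H]1C[C@H](NS(=O)(=O)c2ccc(-c3ccccc3)cc2)CN1S(=O)(=O)c1ccc(Cl)c(Cl)c1` differs from compound 3 in that (the two compounds have the same atoms and bonds and differ only in configuration as drawn: 1 of 2 stereo elements differ; a stereocentre at a saturated ring carbon is drawn R in compound 3 and S in compound 4), the same kind of inversion that separates compound 2 from compound 1. The step from compound 3 to compound 4 is therefore expected to raise the number substantially, by about a 10-fold higher number from compound 3 to compound 4 (1.01 log units; beyond the scatter). Compound 4 is estimated at 6000 nM, within a range of 1500 nM to 30000 nM, with a real chance that no number is reported.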

Compound 4, half-maximal inhibitory concentration: 60 nM
Compound 4: the middle estimate sits 100-fold (2.00 log units) above what was measured; the whole stated range lies above it.
By their numbers in this assay, from the lowest: compounds 4 and 1 (each within the scatter of the next); then compound 3.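

In this assay the inversion at this ring carbon gives a 9.8-fold lower number from compound 3 to compound 4 (0.99 log units; beyond the scatter), so the inversion does not always cost activity, as the pair of compound 1 and compound 2 alone might suggest. Read from the drawn structures, compound 4 shares this ring carbon's arrangement with the inactive compound 2, and compound 3 shares it with the active compound 1, so the favoured arrangement reverses between the thiophene amide and the biphenylsulfonamide. The whole of this step belongs to that one carbon: the fact that compounds 3 and 4 differ only in the configuration as drawn.

From the compounds shown here alone, whether the preference follows the amide or sulfonamide link, or the thiophene or biphenyl beyond it, remains open. So does which arrangement would be favoured with a plain amine or an acetamide at this ring carbon.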